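This account rests on a few compounds, and the source may have more. Where it says the series, first, only, none or still open, it means among the compounds named here.

Measured compounds:
- compound 1, `COCOc1cc(/C=C/C(=O)OCC(=O)Nc2ccc(OC)cc2)ccc1OCc1ccccc1`: 133000 nM
- compound 2, `COCOc1cc(/C=C/C(=O)OCC(=O)Nc2ccc(Cl)cc2)ccc1OCc1ccccc1`: > 200000 nM
- compound 3, `O=C(COC(=O)/C=C/c1ccc(O)c(O)c1)Nc1ccc(Cl)cc1`: > 200000 nM

The three compounds were tested in a functional assay on BEL-7404 cells (Homo sapiens) for cytotoxicity, read by MTT assay, with a stated time of 72 h; a higher number here means a weaker inhibitor, a lower number a stronger inhibitor. In this assay compound 1 gives 133000 nM. Compound 2 reaches only a limit of the assay, > 200000 nM. Compound 3 likewise returns only a limit, > 200000 nM. Two of the three values therefore sit at the same limit, (the limit of > 200000 nM in this assay, at which 2 of the 3 values shown sit).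

Compound 2 and compound 1 differ in one place, (methoxy in place of chloro on an aromatic carbon). This change made an at least 1.5-fold lower number from compound 2 to compound 1 (0.17 log units; that floor lies within the scatter). Since compound 2 is known only as a limit, the true size of that step cannot be fixed.

Compound 4, `COc1ccc(NC(=O)COC(=O)/C=C/c2ccc(O)c(O)c2)cc1`, has not yet been measured in this assay. It stands to compound 3 as compound 1 stands to compound 2: methoxy in place of chloro on an aromatic carbon. The two pairs share the same change at the same kind of place. How the core of compound 3 differs from the core of compound 2 is not broken down here.

Given that compound 3 shows only a limit, > 200000 nM, and that the same change gave an at least 1.5-fold lower number from compound 2 to compound 1 (0.17 log units; that floor lies within the scatter), compound 4 is expected to land near the weak end of the range, with a step of about an at least 1.3-fold lower number from compound 3 to compound 4 (0.12 log units; that floor lies within the scatter). Compound 4 is estimated at 150000 nM, most likely between 70000 nM and 300000 nM, with a fair chance that the assay again returns only a limit.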

Compound 4, half-maximal inhibitory concentration: > 200000 nM
Compound 4: no number, only a limit (the forecaster's own chance of this, stated with the estimate: 45%); at least 1.3-fold (0.12 log units) between middle value and limit.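

Compound 3 and compound 4 both return only a limit in this assay, so the step between them, methoxy in place of chloro on an aromatic carbon, cannot be read: the limit of > 200000 nM in this assay, at which 3 of the 4 values shown sit.

The compounds shown leave open whether this change alters the result at all on the core of compound 3, and how far compound 2, compound 3 and compound 4 truly lie from that limit.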